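A few compounds are considered here, and "the series" means these few. Any claim that something is new, unique, unknown or untested is made for them only; others in the source may bear on it.

Measured compounds:
compound 1 `CC(C)Cc1ccc(C(C)c2nnc3n2N=C(c2ccc(Cl)cc2)CS3)cc1`: 5700 nM
compound 2 `CC(c1ccc(-c2ccccc2)c(F)c1)c1nnc2n1N=C(c1ccccc1)CS2`: 6700 nM
compound 3 `CC(c1ccc(-c2ccccc2)c(F)c1)c1n[nH]c(=S)n1N`: 43100 nM

These three numbers come from a functional assay on Huh-7 cells (Homo sapiens) for inhibition, read by sulforhodamine B assay, with a stated time of 72 h; on this read-out higher numbers stand for weaker inhibition and lower numbers for stronger inhibition. Compound 2 gives the second highest of the three; compound 1 lies so close that the two cannot be told apart, while compound 3 gives a clearly higher number, so compound 3 inhibits more weakly than compound 2. Compound 4 `COc1ccc(C2=Nn3c(nnc3C(C)c3ccc(-c4ccccc4)c(F)c3)SC2)cc1` differs from compound 2 in one place: methoxy in place of hydrogen on an aromatic carbon, para to a large group. For the measured compounds named here, no pair of measured compounds shows this exact change, so there is no direct guide. Without one, the expectation in this assay is a small step, in no clear direction, none beyond the scatter. Compound 4 is therefore estimated at 5500 nM, with a range from 2500 nM to 12000 nM. This estimate means an expected step of a 1.2-fold lower number from compound 2 to compound 4 (0.09 log units; within the scatter).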

Compound 4, half-maximal inhibitory concentration: 4300 nM
Estimate against measurement, compound 4: 1.3-fold (0.11 log units) above, within the range that was stated.
By their numbers in this assay, from the lowest: compounds 4, 1 and 2 (each within the scatter of the next); then compound 3.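

Replacing hydrogen with methoxy, which turns phenyl into 4-methoxyphenyl, gives a 1.6-fold lower number from compound 2 to compound 4 (0.19 log units; within the scatter) in this assay and so leaves the two compounds indistinguishable. For the compounds shown here, this is the first view of this position, and it shows that adding the methoxy here brings no change that can be told from ordinary repeat variation. No measurement is available that would explain this result.

A single pair cannot show how far this holds for other groups at this position. Going by these compounds, whether an amine or a carboxylic acid in the same place would move the number beyond the scatter remains open.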